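Swapping pyrrolidinyl for methyl(tert-butyl)amino: tolerability outlook

This account rests on a few compounds, and the source may have more. Where it says the series, first, only, none or still open, it means among the compounds named here.

Compound 3 `CC(C)(C)CCn1nc(N2CCCC2)c(O)c(C2=NS(=O)(=O)c3cc(NS(C)(=O)=O)ccc3N2)c1=O` was examined in an ADME assay on Huh-7 cells (Homo sapiens) for cytotoxicity, with a stated time of 72 h (a higher number here means that more compound is tolerated, a lower number that less compound is tolerated), where compound 3 gives > 10000 nM, which is a limit of the assay rather than a number. Compound 2 `CC(C)CCn1nc(N2CCCCC2C)c(O)c(C2=NS(=O)(=O)c3cc(NS(C)(=O)=O)ccc3N2)c1=O` likewise reaches only a limit in this assay, namely > 10000 nM. Compound 1 `CCCN(C)c1nn(CCC(C)C)c(=O)c(C2=NS(=O)(=O)c3cc(NS(C)(=O)=O)ccc3N2)c1O` stops at a different limit in this assay, > 1000 nM. Among the compounds with values here, the one measured step, a step that the two limits leave unreadable from compound 1 to compound 2, cannot be read from the two limits involved (the limit of > 1000 nM in this assay, at which 1 of the 3 values shown sits, (the limit of > 10000 nM in this assay, at which 2 of the 3 values shown sit)). Compound 4 `CN(c1nn(CCC(C)(C)C)c(=O)c(C2=NS(=O)(=O)c3cc(NS(C)(=O)=O)ccc3N2)c1O)C(C)(C)C` differs from compound 3 by methyl(tert-butyl)amino in place of pyrrolidin-1-yl on an aromatic carbon. Within the data shown here, no measured step speaks to this change, so for compound 4 the expected step that the limit leaves unreadable from compound 3 to compound 4 in this assay is merely one that leaves it again at a limit. Compound 4 is therefore estimated at 20000 nM, with a range from 8000 nM to 60000 nM.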

Compound 4, half-maximal cytotoxic concentration: > 33000 nM
Compound 4 gave a limit, no number; the forecaster's own chance of this, stated with the estimate: 85%; middle value at least 1.6-fold (0.21 log units) from the limit.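

Compound 3 and compound 4 both stop at limits in this assay, so the step between them cannot be read. The compounds shown leave open at what concentration any of them becomes cytotoxic.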